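This account rests on a few compounds, and the source may have more. Where it says the series, first, only, none or still open, it means among the compounds named here.

Compound 1 `CS(=O)(=O)c1ccc(C(=O)N2CCC(N(C3CC3)S(=O)(=O)c3cccc(C(F)(F)F)c3)CC2)cc1`: "not determined" (no result reported).
Compound 2 `CS(=O)(=O)c1ccccc1C(=O)N1CCC(N(C2CC2)S(=O)(=O)c2cccc(C(F)(F)F)c2)CC1`: 39%.

Among the measured compounds shown here, compound 2 stands alone here: its value in an assay on cells for inhibition of Voltage-dependent L-type calcium channel subunit alpha-1C (Homo sapiens), read by FLIPR and calcium flux, tested at 3 uM (a lower number here means a weaker effect, a higher number a stronger effect of the compound at the concentration tested), is the only number in this set, since compound 1 has none. Compound 3 `CN(C)c1cccc(C(=O)N2CCC(N(C3CC3)S(=O)(=O)c3cccc(C(F)(F)F)c3)CC2)c1` differs from compound 2 in one place, (3-(dimethylamino)phenyl in place of 2-(methylsulfonyl)phenyl on a carbonyl carbon). For the measured compounds named here, no step between measured compounds is known, so the size of this change cannot be read from earlier pairs. The expectation is a shift of a number 7 percentage points lower from compound 2 to compound 3 (within the scatter) in this assay, no larger than the usual scatter, with a wide margin either way. Compound 3 is therefore estimated at 32%, between 10% and 55%.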

Compound 3, a percentage reported as inhibition, at one concentration (the size of the read-out at that concentration, not a potency): 63%
For compound 3 the middle estimate is 31 percentage points below the measured one; the measured number lies above the stated range.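

The group on the carbonyl carbon clearly influences the result: in this assay, replacing 2-(methylsulfonyl)phenyl with 3-(dimethylamino)phenyl gives a number 24 percentage points higher from compound 2 to compound 3 (beyond the scatter). This first measured step shows that the shared core can keep its effect, and even gain some, when this group changes. No available evidence explains the rise.

The swap alters both the group and its printed ring position, so these two contributions cannot be separated. Going by these compounds, whether a methoxy group or a nitrile at the same ring position would give a similar reading remains open.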